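The source may report more compounds than this note shows. Statements on the series, on what has been measured and on what is new or still open speak of the compounds shown alone.

Measured so far:
compound 1 `C[C@@H]1O[C@@H](OCC#Cc2c(-c3ccccc3)oc3ccccc23)CC[C@@H]1N`: 20.2% in an assay on isolated protein for inhibition of DNA topoisomerase 1 (Homo sapiens), with a stated time of 30 min, tested at 100 uM; on this read-out lower numbers stand for less inhibition and higher numbers for more inhibition at the one concentration tested (going by the name of the read-out)
compound 2 `C[C@@H]1O[C@@H](OCC#Cc2c(-c3ccccc3)oc3ccccc23)C[C@H](N)[C@H]1O`: 25.5% in this assay

Compound 2 has the higher of the two numbers, but the step of a number 5.3 percentage points higher from compound 1 to compound 2 (within the scatter) is within the scatter, so the two stand level. Compound 3 `C[C@@H]1O[C@@H](OCC#Cc2c(-c3ccccc3)oc3ccccc23)C[C@H](N)[C@@H]1O` differs from compound 2 only as follows: the two compounds have the same atoms and bonds and differ only in configuration as drawn: 1 of 4 stereo elements differ; a stereocentre at a saturated ring carbon is drawn R in compound 2 and S in compound 3. For the measured compounds named here, no measured step changes a stereocentre, and the only step in hand, a number 5.3 percentage points higher from compound 1 to compound 2 (within the scatter), concerns a different change and was itself small. No step beyond the scatter is therefore expected for compound 3 in this assay, estimated as a number 2.5 percentage points lower from compound 2 to compound 3 (within the scatter). Compound 3 is expected at 23%, within 8% to 40%.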

Compound 3, a percentage reported as inhibition, at one concentration (the size of the read-out at that concentration, not a potency): 77.8%
For compound 3 the middle estimate is 54.8 percentage points below the measured one; the whole stated range lies below it.
By their numbers in this assay, from the lowest: compounds 1 and 2 (each within the scatter of the next); then compound 3.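

In this assay the configuration at this saturated ring carbon has a large influence, with a number 52.3 percentage points higher from compound 2 to compound 3 (beyond the scatter), and this step involves no change in atoms or bonds: the fact that compounds 2 and 3 differ only in the configuration as drawn. The group of 9 heavy atoms also gives a number 57.6 percentage points higher from compound 1 to compound 3 (beyond the scatter) when the stereocentre is drawn S, whereas the same group drawn R in compound 2 stands level with compound 1, so what that group adds depends on configuration here. From the compounds shown here alone, it remains open whether an acetamide or a dimethylamino group in place of the amine would keep the higher number seen for compound 3. Potency also remains open, since these numbers come from one concentration.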